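Title: A Halogen Swap on the Benzylidene Arm

The compounds below may be only part of what the source reports. "The series", "measured", "known", "first", "only" and "open" are said of these compounds alone.

Of the compounds shown here, three of a shared core have been tested, and a fourth awaits. Compound 1, `COc1ccccc1/C=c1\c(=O)[nH]/c(=C/c2cccc(Cl)c2Cl)c(=O)n1C`, is the strongest of the measured set; in a functional assay on U-937 cells (Homo sapiens) for cytotoxicity, read by CCK-8 assay, with a stated time of 72 h (a lower number here means a stronger inhibitor, a higher number a weaker inhibitor), compound 1 gives 100 nM. Compound 2, `C=CCn1c(=O)/c(=C\c2ccc(Cl)c(Cl)c2)[nH]c(=O)/c1=C\c1ccccc1`, was reported in this assay as "not active" (no number reported), with no number attached. Compound 3, `C=CCn1c(=O)/c(=C\c2cccc(F)c2)[nH]c(=O)/c1=C\c1ccccc1OC`, stands highest of the two numbers: in this assay compound 3 gives 2500 nM, a value well beyond the scatter from that of compound 1.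

The unmeasured compound 4, `C=CCn1c(=O)/c(=C\c2cc(Br)ccc2F)[nH]c(=O)/c1=C\c1ccccc1OC`, differs from compound 3 at one place only: 5-bromo-2-fluorophenyl in place of 3-fluorophenyl on a double-bonded chain carbon bound to an aromatic carbon. Among the measured compounds shown here, no measured pair in this set isolates such a change, so nothing here shows what it does on its own. For the measured compounds named here, the only reference point is compound 3 itself, and the substitution keeps the same ring type and the same count of donors and acceptors.

Compound 4 is therefore expected to remain in the neighbourhood of compound 3, with the step of a 1.7-fold lower number from compound 3 to compound 4 (0.22 log units; within the scatter) estimated as modest and not clearly beyond the scatter. On that basis compound 4 is estimated at 1500 nM in this assay, with a range from 400 nM to 6000 nM.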

Compound 4, half-maximal inhibitory concentration: 4700 nM
Compound 4: the middle estimate sits 3.1-fold (0.50 log units) below what was measured; low and high end bracket the measured number.
By their numbers in this assay, from the lowest: compound 1; then compounds 3 and 4 (each within the scatter of the next).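

In this assay, among the compounds shown here, putting 5-bromo-2-fluorophenyl in place of 3-fluorophenyl on a double-bonded chain carbon bound to an aromatic carbon gives a 1.9-fold higher number from compound 3 to compound 4 (0.27 log units; within the scatter), the first step in this set that isolates a change at one place. The position therefore takes a ring with one more heavy atom, a bromine, with no difference that this assay can resolve, and the entering and leaving groups have the same ring type and no hydrogen-bond donors or acceptors. Nothing available bears on why the two compounds read alike.

The compounds shown do not separate the contribution of the bromine from that of the altered fluorine placement, as both differ together in this one step, so a plain 2-fluorophenyl group would be needed to divide them. They also leave open whether this position stays as undemanding with a group of another kind on the ring, such as an amine or a carboxylic acid, which would test it beyond halogens alone.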